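Capping the Piperazine: Predicting Hepatic Extraction of Compound 4

The compounds below may be only part of what the source reports. "The series", "measured", "known", "first", "only" and "open" are said of these compounds alone.

Three measured compounds share one core and differ only in the group attached to an aromatic carbon. In an ADME assay on microsomes from liver (Homo sapiens), read by LC-MS, with a stated time of 60 min, tested at 1 uM (on this read-out lower numbers stand for lower hepatic extraction and higher numbers for higher hepatic extraction), compound 1 `O=C1CN(c2nccn3c(-c4ccc5c(c4)CC(=O)N5)c(-c4ccc(F)cc4)nc23)CCN1` gives 0.7, compound 2 `O=C1Cc2cc(-c3c(-c4ccc(F)cc4)nn4c(N5CCC(F)CC5)nccc34)ccc2N1` gives 0.6, and compound 3 `O=C1CN(c2nccc3c(-c4ccc5c(c4)CC(=O)N5)c(-c4ccc(F)cc4)nn23)CCN1` gives 0.7. Compound 3 stands level with compound 1 at the digits shown, and the step a number 0.10 higher from compound 2 to compound 3 (within the scatter) lies within the scatter. Compound 4 `CC(=O)N1CCN(c2nccc3c(-c4ccc5c(c4)CC(=O)N5)c(-c4ccc(F)cc4)nn23)CC1` carries a change at that same aromatic carbon: 4-acetylpiperazin-1-yl in place of 3-oxopiperazin-1-yl on an aromatic carbon. Among the compounds with values here, the only step that bears on this, from compound 2 to compound 3, also exchanged the group on this carbon and stayed within the scatter, so no shift beyond the scatter is expected here. The step of no change at the digits printed from compound 3 to compound 4 (within the scatter) is therefore expected to be small. Compound 4 is estimated at 0.7, within 0.55 to 0.85.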

Compound 4, hepatic extraction ratio: 0.6
Beside the measured number, compound 4's estimate is 0.10 above it; the measured number falls inside the stated range.
By their numbers in this assay, from the lowest: compounds 2, 4, 1 and 3 (each within the scatter of the next).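

Exchanging 3-oxopiperazin-1-yl for 4-acetylpiperazin-1-yl, which removes the amide hydrogen and adds an acetyl group, gives a number 0.10 lower from compound 3 to compound 4 (within the scatter) in this assay. Set against 4-fluoropiperidin-1-yl, the same group gives no change at the digits printed from compound 2 to compound 4 (within the scatter), so none of the three groups on this aromatic carbon separates from the others. Nothing measured here accounts for these small steps.

Still open, as far as these compounds go, is whether an unsubstituted piperazine, a carboxylic acid or a longer chain on this carbon would shift hepatic extraction beyond the scatter. Also open, from the compounds shown here alone, is whether 4-acetylpiperazin-1-yl would behave the same way on the core of compound 1.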